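Acetoxymethyl in place of cyano on the shared core

This account rests on a few compounds, and the source may have more. Where it says the series, first, only, none or still open, it means among the compounds named here.

Among the compounds with values here, in a functional assay on the whole organism with Rattus norvegicus as the target, with a stated time of 4 h, at a dose of 40 mg/kg by the intraperitoneal route (on this read-out lower numbers stand for less inhibition and higher numbers for more inhibition at the one dose given (going by the name of the read-out)), compound 1 `Cc1nc2c(OCc3ccccc3)cccn2c1C#N` gives 25%, the lower of the two numbers measured so far; its nearest neighbour is compound 2 `Cc1nc2c(OCc3ccccc3)cccn2c1CCC#N`, which in this assay gives 40%. Within the data shown here, the one step between measured compounds, a number 15 percentage points higher from compound 1 to compound 2 (beyond the scatter), exchanges the cyano for a longer chain. Compound 3 `CC(=O)OCc1c(C)nc2c(OCc3ccccc3)cccn12` is not yet measured; it differs from compound 1 by acetoxymethyl in place of cyano on an aromatic carbon. Among the measured compounds shown here, the change again removes the cyano and puts a chain of several heavy atoms in its place, so the step of a number 15 percentage points higher from compound 1 to compound 2 (beyond the scatter) is the only measured step that bears on it, and it was modest. A step of about the same size and direction is therefore expected, and the estimate for compound 1 to compound 3 is a number 10 percentage points higher from compound 1 to compound 3 (within the scatter). For compound 3 the expected value in this assay is 35%, with a range from 15% to 55%.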

Compound 3, a percentage reported as inhibition, in the whole organism at one dose (the size of the read-out at that dose, not a potency): 88%
Compound 3: the middle estimate sits 53 percentage points below what was measured; the measured number lies above the stated range.
By their numbers in this assay, from the lowest: compound 1; then compound 2; then compound 3.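

In this assay, within the data shown here, the aromatic carbon that carries the cyano in compound 1 responds far more strongly than the single earlier step suggested: acetoxymethyl in place of cyano gives a number 63 percentage points higher from compound 1 to compound 3 (beyond the scatter), whereas 2-cyanoethyl gave only a number 15 percentage points higher from compound 1 to compound 2 (beyond the scatter). Removing the cyano is therefore not what sets the size of the step, and what the chain carries matters: acetoxy in place of cyanomethyl on the saturated chain carbon bound to the aromatic carbon gives a number 48 percentage points higher from compound 2 to compound 3 (beyond the scatter). Nothing at hand accounts for the size of this gain.

Open, from the compounds shown here alone, is whether the gain needs the acetoxy group itself, or whether a hydroxymethyl, a methoxymethyl or an aminomethyl on the same carbon would read alike. Also open, going by these compounds, is how a longer acyl chain on the oxygen would read, and all readings here come from one dose and one time.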